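The source may hold more compounds than are shown below. What is called first, only, known or untested is meant among the compounds shown, and "the series" means these compounds.

Of the compounds shown here, two have so far been measured in an ADME assay on a cell-free system (plasma, Rattus norvegicus) for metabolic stability; on this read-out higher numbers stand for a longer-lived compound and lower numbers for a shorter-lived compound. Compound 1 (`Cc1ccc(/N=N/c2sc(N3Nc4onc(-c5ccccc5)c4C3c3ccc(Cl)cc3)nc2C)cc1`) gives 5.72 h, and compound 2 (`Cc1nc(N2Nc3onc(-c4ccccc4)c3C2c2ccc(Cl)cc2)sc1/N=N/c1ccc(Br)cc1`) gives 4.07 h, the lower of the two numbers. Within the data shown here, the only measured step, a 1.4-fold lower number from compound 1 to compound 2 (0.15 log units; within the scatter), swaps bromo for methyl on an aromatic carbon, and its size stays within the scatter, so the two values cannot be told apart with confidence.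

Compound 3 (`Cc1nc(N2Nc3onc(-c4ccccc4)c3C2c2ccc(Cl)cc2)sc1/N=N/c1ccc([N+](=O)[O-])cc1`) has not yet been measured. It differs from compound 2 by nitro in place of bromo on an aromatic carbon; the same difference, cut one bond further out, reads 4-bromophenyl to 4-nitrophenyl.

The step from compound 1 to compound 2 is the only one that bears on this change, as it touches the same aromatic carbon, and it was within the scatter. Among the measured compounds shown here, no measured step involves nitro at all. On this basis no step beyond the scatter is expected in this assay, in either direction. Compound 3 is therefore estimated at 4 h, with a range from 2 h to 8 h. The expected step is a 1.0-fold lower number from compound 2 to compound 3 (0.01 log units; within the scatter).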

Compound 3, half-life: 6.08 h
Beside the measured number, compound 3's estimate is 1.5-fold (0.18 log units) below it; the range from low to high includes it.
By their numbers in this assay, from the lowest: compounds 2, 1 and 3 (each within the scatter of the next).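

In this assay, a third group now sits on the same aromatic carbon, and swapping it in gives a 1.5-fold higher number from compound 2 to compound 3 (0.17 log units; within the scatter) and a 1.1-fold higher number from compound 1 to compound 3 (0.03 log units; within the scatter). Nitro is larger than bromo and carries hydrogen-bond acceptors where bromo has none, yet compound 1, compound 2 and compound 3 all lie within the scatter of one another, so this read-out does not separate these three groups at this position. Nothing available explains this lack of separation, and no outside measurement bears on it.

From the compounds shown here alone, all three groups are small and neutral, so it remains open whether the half-life would stay in the same narrow band with an amine, a carboxylic acid or a longer chain such as butoxy on this aromatic carbon. Every compound shown also shares the rest of its structure, so these results say nothing about how changes elsewhere on the shared core, such as replacing the azo link or the chlorophenyl group, would affect the half-life.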